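Removing the amino group from compound 1

This account rests on a few compounds, and the source may have more. Where it says the series, first, only, none or still open, it means among the compounds named here.

Measured so far in a functional assay on the whole organism with Mus musculus as the target (on this read-out lower numbers stand for an effect already at smaller amounts and higher numbers for an effect only at larger amounts of compound), are three compounds
compound 1 `COc1cc2c(cc1OC)C(c1ccc(N)cc1)=NN=C(S)C2` gives 17.1 umol/kg
compound 2 `COc1cc2c(cc1OC)C(c1ccccc1)=NNC(=O)C2` gives 66 umol/kg
compound 3 `COc1cc2c(cc1OC)C(c1ccc(N)cc1)=NNC(=O)C2` gives 32.1 umol/kg

Compound 1 lies within the usual scatter of compound 3 and clearly lower than compound 2 on these numbers, which places it at the low end of this small set. The unmeasured compound 4 `COc1cc2c(cc1OC)C(c1ccccc1)=NN=C(S)C2` departs from compound 1 at a single place: hydrogen in place of amino on an aromatic carbon with hydrogen in place of amino on an aromatic carbon, so that 4-aminophenyl becomes phenyl.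

Among the compounds with values here, one measured step bears on this change. It is the same exchange in the opposite direction on a different version of the shared core, a 2.1-fold lower number from compound 2 to compound 3 (0.31 log units; beyond the scatter) and it is modest but beyond the scatter. Run in reverse, that step suggests a modest rise of similar size in this assay rather than no change, although a single pair is thin support and the core of compound 1 may not respond alike. The expected change is a 2.0-fold higher number from compound 1 to compound 4 (0.31 log units; beyond the scatter) on this reasoning. Compound 4 is expected near 35 umol/kg with a range of 16 umol/kg to 75 umol/kg as the estimate.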

Compound 4, dose for half-maximal effect: 43.1 umol/kg
The estimate for compound 4 lay 1.2-fold (0.09 log units) below the measured number; low and high end bracket the measured number.
By their numbers in this assay, from the lowest: compounds 1, 3, 4 and 2 (each within the scatter of the next, the first and the last beyond it).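

In this assay, within the data shown here, the change from 4-aminophenyl to phenyl gives a 2.5-fold higher number from compound 1 to compound 4 (0.40 log units; beyond the scatter), so the loss of the amino group now has a reading on a second core, apart from the one shared by compound 2 and compound 3. Among these compounds, the two readings run in the same direction and agree in size, so on these compounds the effect of the exchange does not depend on which of the two cores carries it: the same change on two cores in this assay, a 2.1-fold lower number (0.31 log units; beyond the scatter) from compound 2 to compound 3 and a 2.5-fold lower number (0.40 log units; beyond the scatter) from compound 4 to compound 1, 1.2-fold (0.09 log units) apart, within the scatter of two such steps This holds for two pairs only, one on each core, and no compound among the four goes against it.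

The compounds shown carry only amino or hydrogen at this place on the ring, so it stays open how a hydroxyl, a methoxy, a dimethylamino or an acetamido group would read there, and whether the step belongs to the amino group itself or would come with any of these. From the compounds shown here alone, what lies behind the step also stays open, as does whether an amino group elsewhere on the same ring would lower the number to a similar degree.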